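Chloro to nitro on the outer phenyl ring

The compounds below may be only part of what the source reports. "The series", "measured", "known", "first", "only" and "open" are said of these compounds alone.

Measured so far:
compound 1 `CCOC(=O)CCCCCOc1cccc(CN(C(=O)c2ccc(-c3ccoc3)cc2)C(C)C)c1`: > 26000 nM
compound 2 `CCOC(=O)CCCCCOc1cccc(CN(C(=O)c2ccc(-c3cccc(Cl)c3)cc2)C(C)C)c1`: > 18400 nM

In an ADME assay on Raji cells (Homo sapiens) for cytotoxicity, read by CellTiter-Glo and resazurin assay, with a stated time of 72 h (on this read-out higher numbers stand for an effect only at larger amounts of compound and lower numbers for an effect already at smaller amounts), compound 1 gives > 26000 nM, a limit of the assay and not a number. In this assay compound 2 gives > 18400 nM, also a limit. Among the compounds with values here, compound 2 therefore stands at a limit, and the only other value shown is a limit as well. Within the data shown here, the single measured step, a step that the two limits leave unreadable from compound 1 to compound 2, stays unreadable because the limit of > 18400 nM in this assay, at which 1 of the 2 values shown sits, and the limit of > 26000 nM in this assay, at which 1 of the 2 values shown sits, are both limits, so no size can be drawn from it.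

Compound 3 `CCOC(=O)CCCCCOc1cccc(CN(C(=O)c2ccc(-c3cccc([N+](=O)[O-])c3)cc2)C(C)C)c1` carries the change (nitro in place of chloro on an aromatic carbon). Among the measured compounds shown here, no measured step covers a nitro group, and the one step at hand gives no direction. With compound 2 at a limit, compound 3 is expected to sit near or beyond that limit again, with a step that the limit leaves unreadable from compound 2 to compound 3 expected to be no clear change. The estimate for compound 3 in this assay is 30000 nM, in a range of 8000 nM to 100000 nM.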

Compound 3, half-maximal effective concentration: > 26000 nM
Compound 3: a limit, no number (the forecaster's own chance of this, stated with the estimate: 80%); the middle value is on the limit's open side.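

Within the data shown here, no step among compound 1, compound 2 and compound 3 can be read: all three values are limits of the assay and not numbers. From the compounds shown here alone, whether swapping furan-3-yl, 3-chlorophenyl and 3-nitrophenyl changes the effect on these cells at all stays open, as does the size of any such change.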